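Taking the diethylamino group off compound 3

This account rests on a few compounds, and the source may have more. Where it says the series, first, only, none or still open, it means among the compounds named here.

In a functional assay on HT-29 cells (Homo sapiens) for antiproliferative activity, read by MTT assay, with a stated time of 24 h (on this read-out higher numbers stand for weaker inhibition and lower numbers for stronger inhibition), compound 3 `CCN(CC)c1ccc(/C=C/C(=O)c2ccc(OC)c3c2OC(C)(C)C=C3)cc1` gives 550 nM, the lowest number in this small set. Compound 2 `COc1ccc(C(=O)/C=C/c2ccc(N(C)C)cc2)c2c1C=CC(C)(C)O2` gives 1870 nM. Compound 1 `COc1ccc(C(=O)/C=C/c2ccc(F)cc2)c2c1C=CC(C)(C)O2` gives > 10000 nM, which is a limit of the assay and not a number.

Compound 4 `COc1ccc(C(=O)/C=C/c2ccccc2)c2c1C=CC(C)(C)O2` has hydrogen in place of diethylamino on an aromatic carbon. For the measured compounds named here, no measured step makes this exact change, but three bear on it. The closest is the large step of an at least 18-fold lower number from compound 1 to compound 3 (1.25 log units; beyond the scatter), where diethylamino replaces fluoro. With dimethylamino replacing fluoro, the step of an at least 5.3-fold lower number from compound 1 to compound 2 (0.72 log units; beyond the scatter) is at least modest, and the step of a 3.4-fold lower number from compound 2 to compound 3 (0.53 log units; beyond the scatter) is modest. Judging from compound 1 and the step of an at least 18-fold lower number from compound 1 to compound 3 (1.25 log units; beyond the scatter), a large move to a higher number is expected in this assay, and the result may reach the limit of the assay. The estimated step is a 13-fold higher number from compound 3 to compound 4 (1.10 log units; beyond the scatter). The expected value for compound 4 is 7000 nM, with an estimated range from 2000 nM to 20000 nM.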

Compound 4, half-maximal inhibitory concentration: > 10000 nM
Compound 4: a limit, no number (the forecaster's own chance of this, stated with the estimate: 50%); middle value at least 1.4-fold (0.15 log units) from the limit.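

In this assay, hydrogen on this aromatic carbon gives an at least 18-fold higher number from compound 3 to compound 4 (1.25 log units; beyond the scatter) and an at least 5.3-fold higher number from compound 2 to compound 4 (0.72 log units; beyond the scatter), so a parent without any substituent here does not retain the activity seen with either amine, and in this set only the diethylamino and dimethylamino compounds give numbers below the limit. Compound 4 gives > 10000 nM, which is a limit of the assay and not a number. The step between compound 1 and compound 4 cannot be read, because both values stand at the same limit: the limit of > 10000 nM in this assay, at which 2 of the 4 values shown sit.

The compounds shown leave open whether a simple amino group, a pyrrolidine ring or a dipropylamino group would keep a number below that limit at this position. They also leave open whether a methoxy group, which has no nitrogen, could do the same.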